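The source may report more compounds than this note shows. Statements on the series, on what has been measured and on what is new or still open speak of the compounds shown alone.

In a functional assay on SW480 cells (Homo sapiens) for cytotoxicity, read by MTT assay, with a stated time of 48 h (a lower number here means a stronger inhibitor, a higher number a weaker inhibitor), compound 1 (`COc1cc([C@@H]2C[C@]2(CO)C(=O)Nc2ccccc2Cl)cc(OC)c1OC`) gives 13200 nM and compound 2 (`COc1cc([C@@H]2C[C@]2(CO)C(=O)NCc2ccc(C)cc2)cc(OC)c1OC`) gives 26800 nM. Compound 3 (`COc1cc([C@H]2C[C@]2(CO)C(=O)Nc2ccccc2Cl)cc(OC)c1OC`) gives 40200 nM, a value within the scatter of compound 2. Against compound 1 the gap is real, a 3.0-fold higher number from compound 1 to compound 3 (0.48 log units; beyond the scatter), and it rests on (the fact that compounds 1 and 3 differ only in the configuration as drawn). Compound 4 (`COc1cc([C@H]2C[C@]2(CO)C(=O)NCc2ccc(C)cc2)cc(OC)c1OC`) has 4-methylbenzyl in place of 2-chlorophenyl on an amide-type nitrogen. The same exchange has been measured once, in the other drawn configuration, as a 2.0-fold higher number from compound 1 to compound 2 (0.31 log units; beyond the scatter), a modest step. A similar modest rise is therefore expected in this assay, an estimated 1.6-fold higher number from compound 3 to compound 4 (0.21 log units; within the scatter). For compound 4 the estimate is 65000 nM, with an expected range from 30000 nM to 140000 nM.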

Compound 4, half-maximal inhibitory concentration: 94000 nM
Estimate against measurement, compound 4: 1.4-fold (0.16 log units) below, within the range that was stated.
By their numbers in this assay, from the lowest: compound 1; then compounds 2 and 3 (each within the scatter of the next); then compound 4.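

With this assay, the exchange of 2-chlorophenyl for 4-methylbenzyl on an amide-type nitrogen can now be read in both drawn configurations, here as a 2.3-fold higher number from compound 3 to compound 4 (0.37 log units; beyond the scatter), and the two readings agree: the same change on two cores in this assay, a 2.0-fold higher number (0.31 log units; beyond the scatter) from compound 1 to compound 2 and a 2.3-fold higher number (0.37 log units; beyond the scatter) from compound 3 to compound 4, 1.2-fold (0.06 log units) apart, within the scatter of two such steps. The drawn configuration also separates the 4-methylbenzyl pair, with a 3.5-fold higher number from compound 2 to compound 4 (0.54 log units; beyond the scatter), in the same direction as the 2-chlorophenyl pair: the fact that compounds 2 and 4 differ only in the configuration as drawn.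

The compounds shown leave open what happens with a simple alkyl chain or a benzyl group carrying an amine on that nitrogen. They also leave open whether the gap between the two configurations would persist with such groups.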